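Nitro Substitution Across Two Related Antiproliferative Pairs

The source may report more compounds than this note shows. Statements on the series, on what has been measured and on what is new or still open speak of the compounds shown alone.

Measured so far:
compound 1 `COc1ccc(-c2c(-c3cc(OC)c(OC)c(OC)c3)ssc2=S)cc1`: 1140 nM
compound 2 `COc1ccc(-c2c(-c3cc(OC)c(OC)c(OC)c3)ssc2=S)cc1[N+](=O)[O-]`: 38200 nM
compound 3 `COc1ccc(-c2c(-c3cc(OC)c(OC)c(OC)c3)ss/c2=N/O)cc1`: > 100000 nM (a limit, not a number)

In a functional assay on KB cells (Homo sapiens) for antiproliferative activity, read by MTT assay, with a stated time of 72 h (a lower number here means a stronger inhibitor, a higher number a weaker inhibitor), compound 1 gives 1140 nM. Compound 2 differs by nitro in place of hydrogen on an aromatic carbon, and the step is a 34-fold higher number from compound 1 to compound 2 (1.53 log units; beyond the scatter). Compound 3 has a different core; how the cores of compound 1 and compound 3 differ is not broken down here. For compound 3 this assay reports only a limit, > 100000 nM, which is the limit of > 100000 nM in this assay, at which 1 of the 3 values shown sits. Compound 4 `COc1ccc(-c2c(-c3cc(OC)c(OC)c(OC)c3)ss/c2=N/O)cc1[N+](=O)[O-]` is not yet measured; it carries the same change as the measured pair, (nitro in place of hydrogen on an aromatic carbon), at a place described in identical words. The expected step is a step that the limit leaves unreadable from compound 3 to compound 4, resting on a 34-fold higher number from compound 1 to compound 2 (1.53 log units; beyond the scatter) and on the limit already reached by compound 3. Compound 4 is therefore estimated at 300000 nM, from 100000 nM to 3000000 nM, most likely reported again only as a limit.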

Compound 4, half-maximal inhibitory concentration: 5260 nM
Beside the measured number, compound 4's estimate is 57-fold (1.76 log units) above it, outside the stated range (below it).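

In this assay, nitro in place of hydrogen on an aromatic carbon gives an at least 19-fold lower number from compound 3 to compound 4 (1.27 log units; beyond the scatter), so the change does not carry over from the core of compound 1 to the core of compound 3 with the same direction: the same change on two cores in this assay, a 34-fold higher number (1.53 log units; beyond the scatter) from compound 1 to compound 2 and an at least 19-fold lower number (1.27 log units; beyond the scatter) from compound 3 to compound 4, at least 630-fold (2.80 log units) apart, beyond the scatter of two such steps

Compound 3 gives only a limit, > 100000 nM, so the step on this core is a bound and not an exact size: the limit of > 100000 nM in this assay, at which 1 of the 4 values shown sits.

These two pairs show that the outcome of this change depends on the core, but not which feature of the cores decides it, nor how it would go on any further core.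

Open, from the compounds shown here alone, is whether an amine in place of the nitro would split the same way on the two cores. Also open, going by these compounds, is whether a carboxylic acid at that place would do so.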